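The source may report more compounds than this note shows. Statements on the series, on what has been measured and on what is new or still open speak of the compounds shown alone.

Compound 1 `COc1cc(/C=C/C(=O)/C=C/c2ccco2)ccc1OCc1cn(CCCOc2cc(=O)oc3ccccc23)nn1`: 51%
Compound 2 `COc1ccccc1/C=C/C(=O)/C=C/c1ccc(OCc2cn(CCCCCOc3cc(=O)oc4ccccc34)nn2)c(OC)c1`: 33%
Compound 3 `COc1cc(/C=C/C(=O)/C=C/c2ccco2)ccc1OCc1cn(CCOc2cc(=O)oc3ccccc23)nn1`: 72%

In a functional assay on HCT-116 cells (Homo sapiens) for inhibition, read by sulforhodamine B assay, with a stated time of 48 h, tested at 50 uM (a lower number here means less inhibition of growth, a higher number more inhibition of growth at the concentration tested), compound 1 gives 51% and stands second highest of these three numbers, above compound 2 and below compound 3, with both gaps beyond the scatter. Compound 4 `COc1cc(/C=C/C(=O)/C=C/c2cc(OC)c(OC)c(OC)c2)ccc1OCc1cn(CCCOc2cc(=O)oc3ccccc23)nn1` carries 3,4,5-trimethoxyphenyl in place of furan-2-yl on a double-bonded chain carbon bound to a double-bonded chain carbon. Among the compounds with values here, no measured pair isolates this change. Compound 2, which also has no furan-2-yl, gives 33% but differs in its chain too, so only a modest fall in this assay is expected, about the size of the scatter. In numbers, the estimate is a number 9 percentage points lower from compound 1 to compound 4 (within the scatter) as the expected step. For compound 4 the expected value is 42% with an estimated range (24% to 60%).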

Compound 4, percent growth inhibition at one concentration: 76%
Compound 4: middle estimate off by 34 percentage points, on the low side; measured number outside the range, above it.
By their numbers in this assay, from the lowest: compound 2; then compound 1; then compounds 3 and 4 (each within the scatter of the next).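

In this assay, within the data shown here, the swap of furan-2-yl for 3,4,5-trimethoxyphenyl gives a number 25 percentage points higher from compound 1 to compound 4 (beyond the scatter) and is the first reading of a change at this place with the rest of the molecule held fixed. This place on the chain therefore tolerates the larger aromatic group, and growth inhibition rises rather than falls. Nothing measured here explains the rise.

Open, going by these compounds, is whether a phenyl ring bearing a dimethylamino group or a carboxylic acid would behave the same way here, and whether this step carries over to the chain of compound 3.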